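Urea analogues of a zebrafish kinase inhibitor

This account rests on a few compounds, and the source may have more. Where it says the series, first, only, none or still open, it means among the compounds named here.

The three measured compounds share one core and differ only in the group on the terminal urea nitrogen. Compound 1 `COc1cccc(NC(=O)Nc2ccc(Oc3ncnc4[nH]ncc34)cc2)c1` carries a 3-methoxyphenyl there, compound 2 `Cc1cccc(NC(=O)Nc2ccc(Oc3ncnc4[nH]ncc34)cc2)c1C` a 2,3-dimethylphenyl, and compound 3 `O=C(Nc1ccc(Oc2ncnc3[nH]ncc23)cc1)Nc1cccnc1` a pyridin-3-yl. In an assay on isolated protein for inhibition of vascular endothelial growth factor receptor 2 (Danio rerio), read by fluorescence and microscopy, with a stated time of 33 h (on this read-out higher numbers stand for weaker inhibition and lower numbers for stronger inhibition), compound 1 gives 82000 nM and compound 2 gives 98800 nM. Compound 3 reaches only a limit, > 100000 nM. Among the three values shown, compound 3 is the one that sits at the limit of > 100000 nM in this assay, at which 1 of the 3 values shown sits. The steps between the measured compounds are a 1.2-fold higher number from compound 1 to compound 2 (0.08 log units; within the scatter), an at least 1.2-fold higher number from compound 1 to compound 3 (0.08 log units; that floor lies within the scatter) and an at least 1.0-fold higher number from compound 2 to compound 3 (0.00 log units; that floor lies within the scatter); each lies within the scatter.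

Compound 4 `O=C(Nc1ccc(Oc2ncnc3[nH]ncc23)cc1)NC1CCCCC1` is not yet measured. Compared with compound 3 it has cyclohexyl in place of pyridin-3-yl on an amide-type nitrogen. Going by the values given here, no measured step exchanges an aromatic ring for a non-aromatic one on this nitrogen, so none bears directly on this change; the three steps that do exist all lie within the scatter, and none of the three compounds has moved the number far. The expected step in this assay is therefore a step that the limit leaves unreadable from compound 3 to compound 4, nothing beyond the scatter. Compound 4 is estimated at 120000 nM, between 40000 nM and 400000 nM, with a fair chance that this assay again reports only a limit.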

Compound 4, half-maximal inhibitory concentration: > 100000 nM
Compound 4: only a limit was reported; the forecaster's own chance of this, stated with the estimate: 60%; the middle value lies beyond the limit too.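

Compound 4 gives > 100000 nM in this assay, which is a limit of the assay and not a number, so the first non-aromatic ring seen on this amide-type nitrogen also gives no value short of that limit. The step from the pyridin-3-yl of compound 3 to this cyclohexyl cannot be read, as both ends are limits, and the two comparisons that can be read are an at least 1.0-fold higher number from compound 2 to compound 4 (0.00 log units; that floor lies within the scatter) and an at least 1.2-fold higher number from compound 1 to compound 4 (0.08 log units; that floor lies within the scatter), neither of which shows a difference beyond the scatter. Exchanging an aromatic ring for a carbon-only, non-aromatic one therefore gives no sign of stronger inhibition, and the limit now holds compound 3 and compound 4: the limit of > 100000 nM in this assay, at which 2 of the 4 values shown sit.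

From the compounds shown here alone, how far compound 3 and compound 4 really lie past the limit stays open, and with it any order between them. Also open, going by these compounds, is whether a carboxylic acid, a primary amine or a longer chain on this nitrogen would move the number beyond the scatter.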